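The source may hold more compounds than are shown below. What is called first, only, known or untested is meant among the compounds shown, and "the series" means these compounds.

Compound 1 `CCc1nncn1-c1ccc(OCc2ccccc2Cl)cc1` is the starting point of this account. In a functional assay on the whole organism (strain C57B/6) with Mus musculus as the target, in the maximal electroshock model (on this read-out higher numbers stand for an effect only at larger amounts of compound and lower numbers for an effect already at smaller amounts), compound 1 gives 13.2 mg/kg, which is the lower of the two numbers recorded so far. Its nearest neighbour is compound 2 `CCc1nncn1-c1ccc(OCc2c(Cl)cccc2Cl)cc1`, which in this assay gives 15.8 mg/kg; the move a 1.2-fold higher number from compound 1 to compound 2 (0.08 log units; within the scatter) places chloro in place of hydrogen on an aromatic carbon and stays within the scatter. Compound 3 `CCCCCCCOc1ccc(-n2cnnc2CC)cc1` remains unmeasured in this assay. It differs from compound 1 by hexyl in place of 2-chlorophenyl on a saturated chain carbon bound to an oxygen on an aromatic ring. Among the compounds with values here, none of the measured steps touches this kind of change: the single step from compound 1 to compound 2 alters only the ring that is now removed, so it offers no direct guide. Within the data shown here, with no precedent for swapping a ring for a chain, the expected step of a 1.5-fold higher number from compound 1 to compound 3 (0.18 log units; within the scatter) is modest and uncertain in direction. Compound 3 is therefore estimated to give about 20 mg/kg in this assay, within a range of 8 mg/kg to 50 mg/kg.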

Compound 3, dose for half-maximal effect: 8.3 mg/kg
For compound 3 the middle estimate is 2.4-fold (0.38 log units) above the measured one; the range from low to high includes it.
By their numbers in this assay, from the lowest: compounds 3, 1 and 2 (each within the scatter of the next).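

Within the data shown here, at the place on a saturated chain carbon bound to an oxygen on an aromatic ring, the earlier compounds showed only a change on the ring itself, whereas compound 3 removes that ring altogether. In this assay, hexyl in place of 2-chlorophenyl gives a 1.6-fold lower number from compound 1 to compound 3 (0.20 log units; within the scatter) and so keeps the number within the scatter. At this place, then, neither the aromatic ring nor its chlorine is required for a number of this size, and the data offer no explanation for how closely the two groups agree.

Going by these compounds, it remains open whether a shorter chain, a longer chain or a chain ending in an amine would hold the number in this range at the same place. Also open, on these data alone, is how plain benzyl, without any chlorine, would compare with compound 1.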